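A few compounds are considered here, and "the series" means these few. Any claim that something is new, unique, unknown or untested is made for them only; others in the source may bear on it.

In a functional assay on the whole organism for inhibition, with Mythimna separata as the target, with a stated time of 5 days (on this read-out lower numbers stand for an effect already at smaller amounts and higher numbers for an effect only at larger amounts of compound), compound 1 `CC(C)(C)n1ncc(OCc2nnc(-c3ccc(Br)cc3)o2)c(Cl)c1=O` gives 21.4 ug/mL, the higher of the two actual numbers at hand. Compound 3 `CC(C)(C)n1ncc(OCc2nnc(-c3cccc(F)c3)o2)c(Cl)c1=O` gives 7.1 ug/mL. Compound 2 `Cc1nnc(COc2cnn(C(C)(C)C)c(=O)c2Cl)o1` is reported only as a limit, > 300 ug/mL. Compound 4 `CC(C)(C)n1ncc(OCc2nnc(-c3ccc(C(F)(F)F)cc3)o2)c(Cl)c1=O` differs from compound 1 by trifluoromethyl in place of bromo on an aromatic carbon, with trifluoromethyl in place of bromo on an aromatic carbon. Two measured steps offer indirect guidance. Methyl in place of 4-bromophenyl gave a large change, an at least 14-fold higher number from compound 1 to compound 2 (1.14 log units; beyond the scatter), but compound 4 keeps the six-membered aromatic ring. 3-Fluorophenyl in place of 4-bromophenyl gave a modest change, a 3.0-fold lower number from compound 1 to compound 3 (0.48 log units; beyond the scatter). A swap of one substituent is expected to fall short of these, and the estimated 1.3-fold lower number from compound 1 to compound 4 (0.10 log units; within the scatter) should stay within the scatter. For compound 4 the estimated value is 17 ug/mL, with an expected range of 6 ug/mL to 50 ug/mL.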

Compound 4, half-maximal effective concentration: 34.1 ug/mL
Estimate against measurement, compound 4: 2.0-fold (0.30 log units) below, and the stated range covers the measured number.
By their numbers in this assay, from the lowest: compound 3; then compounds 1 and 4 (each within the scatter of the next). At a limit, above all of these: compound 2.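

Trifluoromethyl in place of bromo, on an aromatic carbon para to a large group, gives a 1.6-fold higher number from compound 1 to compound 4 (0.20 log units; within the scatter) in this assay. The earlier steps shown here exchanged the whole aryl group, whereas this one exchanges only the substituent on a retained ring, and the read-out does not separate the two compounds. Nothing at hand bears on the reason for this result. As far as these compounds go, what an amine or a carboxylic acid would do at this position stays open. So does whether compound 3 owes its number to the fluoro group itself or to where that group sits.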